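Chain Homologation on the Aryl Sulfonate Ester

This account rests on a few compounds, and the source may have more. Where it says the series, first, only, none or still open, it means among the compounds named here.

Compound 1 `Cc1ccccc1OS(=O)(=O)c1ccc(NC(=O)NCCCCl)cc1`: 27000 nM
Compound 2 `CCc1ccccc1OS(=O)(=O)c1ccc(NC(=O)NCCCCl)cc1`: 15000 nM

In a functional assay on MCF7 cells (Homo sapiens) for cytotoxicity, read by sulforhodamine B assay, with a stated time of 48 h (on this read-out lower numbers stand for stronger inhibition and higher numbers for weaker inhibition), compound 1 gives 27000 nM, and compound 2 gives 15000 nM. Compound 2 thus has the lowest of the two numbers, but its nearest neighbour is compound 1, and the gap between them lies within the scatter.

Compound 3 `CCCc1ccccc1OS(=O)(=O)c1ccc(NC(=O)NCCCCl)cc1` has not yet been measured. It differs from compound 2 by methyl in place of hydrogen on a saturated chain carbon, two bonds along the chain from an aromatic carbon. Going by the values given here, the only measured step that bears on it is a 1.8-fold lower number from compound 1 to compound 2 (0.26 log units; within the scatter), which grew the same chain by one carbon closer to the ring and stayed within the scatter. On that basis, a further methyl added to the chain is expected to give at most a modest change, a 1.5-fold lower number from compound 2 to compound 3 (0.18 log units; within the scatter), probably toward a lower number or none beyond the scatter. Compound 3 is therefore estimated at 10000 nM, within a range from 4000 nM to 30000 nM.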

Compound 3, half-maximal inhibitory concentration: 15000 nM
For compound 3 the middle estimate is 1.5-fold (0.18 log units) below the measured one; the range from low to high includes it.
By their numbers in this assay, from the lowest: compounds 2, 3 and 1 (each within the scatter of the next).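

In this assay the step from ethyl to propyl, on a saturated chain carbon, two bonds along the chain from an aromatic carbon, reads no change at the digits printed from compound 2 to compound 3 (within the scatter) and the full change from methyl to propyl reads a 1.8-fold lower number from compound 1 to compound 3 (0.26 log units; within the scatter). Going by these compounds alone, the small step seen from methyl to ethyl therefore does not build into a trend, as the full change from methyl to propyl also stays within the scatter and no member of this short series separates from the others. Nothing measured here bears on why the number stays flat along this chain.

The compounds shown leave open whether a longer chain such as butyl would finally move the number beyond the scatter. They also leave open whether an amine or a carboxylic acid at the end of the propyl chain would do so.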